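The source may hold more compounds than are shown below. What is called first, only, known or untested is meant among the compounds shown, and "the series" means these compounds.

Values from a functional assay on MV4-11 cells (Homo sapiens) for antiproliferative activity, read by CellTiter-Glo, with a stated time of 72 h (a higher number here means a weaker inhibitor of growth, a lower number a stronger inhibitor of growth), are these:
- compound 1 (`CC(=O)N[C@H]1CC[C@H](Nc2cc(-c3csc(NCC4CCOCC4)n3)c(Cl)cn2)CC1`) gives 3600 nM
- compound 2 (`COCCN[C@H]1CC[C@H](Nc2cc(-c3csc(NCC4CCOCC4)n3)c(Cl)cn2)CC1`) gives 170 nM

Compound 2 holds the lower number of the two and so is the stronger inhibitor of growth. Within the data shown here, the only measured step is large (a 21-fold lower number from compound 1 to compound 2 (1.33 log units; beyond the scatter)) but swaps acetyl for 2-methoxyethyl, a whole group. Compound 3 (`COC[C@@H](C)N[C@H]1CC[C@H](Nc2cc(-c3csc(NCC4CCOCC4)n3)c(Cl)cn2)CC1`) differs from compound 2 in one place (methyl in place of hydrogen on a saturated chain carbon bound to an amine nitrogen and a saturated chain carbon), turning 2-methoxyethyl into 1-(methoxymethyl)ethyl. Among the measured compounds shown here, no measured step covers so small a change, so no shift beyond the scatter, in either direction, is expected in this assay (a 1.1-fold lower number from compound 2 to compound 3 (0.03 log units; within the scatter)). The estimated value for compound 3 is 160 nM (range 55 nM to 480 nM).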

Compound 3, concentration for 50% growth inhibition: 140 nM
Beside the measured number, compound 3's estimate is 1.1-fold (0.06 log units) above it, within the range that was stated.
By their numbers in this assay, from the lowest: compounds 3 and 2 (each within the scatter of the next); then compound 1.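

In this assay, methyl in place of hydrogen on this saturated chain carbon makes no difference beyond the scatter (a 1.2-fold lower number from compound 2 to compound 3 (0.08 log units; within the scatter)), so this carbon accepts a small branch without loss. The large advantage over acetyl on the amine nitrogen also remains (a 26-fold lower number from compound 1 to compound 3 (1.41 log units; beyond the scatter)). Nothing available explains either result. The compounds shown leave open whether an ethyl group or a larger branch such as isopropyl at this carbon would hold the number. They also leave open whether a longer chain ending in a hydroxyl group would do so.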